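A Fluorine Switch on the Benzyl Group

This account rests on a few compounds, and the source may have more. Where it says the series, first, only, none or still open, it means among the compounds named here.

Compound 1 `N#Cc1ccc(Cn2c(/C=C3\SC(=S)N(CC(=O)O)C3=O)nc3ccccc32)cc1`: 9780 nM
Compound 2 `Cc1ccc(Cn2c(/C=C3\SC(=S)N(CC(=O)O)C3=O)nc3ccccc32)cc1`: 960 nM

In a functional assay on Raji cells (Homo sapiens) for cytotoxicity, read by MTT assay, with a stated time of 48 h (on this read-out lower numbers stand for stronger inhibition and higher numbers for weaker inhibition), compound 1 gives 9780 nM, the highest of the two numbers shown. Among the compounds with values here, its only neighbour is compound 2, which in this assay gives 960 nM, and the step of a 10-fold lower number from compound 1 to compound 2 (1.01 log units; beyond the scatter) is large. Compound 3 `O=C(O)CN1C(=O)/C(=C/c2nc3ccccc3n2Cc2cccc(F)c2)SC1=S` is not yet measured; it differs from compound 1 by 3-fluorophenyl in place of 4-cyanophenyl on a saturated chain carbon bound to an aromatic nitrogen. Within the data shown here, the one measured step that bears on this change is a 10-fold lower number from compound 1 to compound 2 (1.01 log units; beyond the scatter), which also replaces the cyano group, though with a different group at a different place on the ring. Because a 10-fold lower number from compound 1 to compound 2 (1.01 log units; beyond the scatter) was large, a lower number is expected for compound 3 than for compound 1, but with less confidence in its size, so the expected step of a 3.9-fold lower number from compound 1 to compound 3 (0.59 log units; beyond the scatter) is set smaller. Compound 3 is therefore estimated at 2500 nM, within the range 800 nM to 8000 nM.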

Compound 3, half-maximal inhibitory concentration: 13300 nM
For compound 3 the middle estimate is 5.3-fold (0.73 log units) below the measured one; the whole stated range lies below it.
By their numbers in this assay, from the lowest: compound 2; then compounds 1 and 3 (each within the scatter of the next).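

In this assay, putting 3-fluorophenyl in place of 4-cyanophenyl on a saturated chain carbon bound to an aromatic nitrogen gives a 1.4-fold higher number from compound 1 to compound 3 (0.13 log units; within the scatter), so this change leaves the read-out unresolved from that of compound 1. The same position does respond to the group it carries, as 3-fluorophenyl in place of 4-methylphenyl gives a 14-fold higher number from compound 2 to compound 3 (1.14 log units; beyond the scatter), and among these three compounds only compound 2 stands apart, beyond the scatter from both others. Nothing available here accounts for these differences.

Compounds 2 and 3 differ both in the substituent and in where it sits on the phenyl ring, so the two contributions remain unseparated. A 4-fluorophenyl or 3-methylphenyl group would address this, while an unsubstituted phenyl group would show how the read-out stands without any substituent.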